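A few compounds are considered here, and "the series" means these few. Any claim that something is new, unique, unknown or untested is made for them only; others in the source may bear on it.

Working notes on the series. Compound 1 `CC1(C)Cc2c(O)ccc(C(=O)/C=C/c3cn(-c4ccccc4)nc3-c3cccc([N+](=O)[O-])c3)c2O1` and compound 2 `CC1(C)Cc2c(O)ccc(C(=O)/C=C/c3cn(-c4ccccc4)nc3-c3ccc(Cl)cc3)c2O1` share one core; compound 3 `CC1(C)Cc2c(ccc(C(=O)/C=C/c3cn(-c4ccccc4)nc3-c3cccc([N+](=O)[O-])c3)c2OCc2ccccc2)O1` and compound 4 `CC1(C)Cc2c(ccc(C(=O)/C=C/c3cn(-c4ccccc4)nc3-c3ccc(Cl)cc3)c2OCc2ccccc2)O1` share another. How the core of compound 1 differs from the core of compound 3 is not broken down here.

In a functional assay on PC-3 cells (Homo sapiens) for antiproliferative activity, read by MTT assay, with a stated time of 48 h (a lower number here means a stronger inhibitor, a higher number a weaker inhibitor), compound 1 gives 25600 nM and compound 2 gives 18000 nM. The change 4-chlorophenyl in place of 3-nitrophenyl on an aromatic carbon therefore produces a 1.4-fold lower number from compound 1 to compound 2 (0.15 log units; within the scatter). For compound 3 only a limit is reported, > 100000 nM, which is the limit of > 100000 nM in this assay, at which 1 of the 3 values shown sits.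

Compound 4 has not yet been measured. Among the compounds with values here, it differs from compound 3 by 4-chlorophenyl in place of 3-nitrophenyl on an aromatic carbon, the same change as the one from compound 1 to compound 2. Because a 1.4-fold lower number from compound 1 to compound 2 (0.15 log units; within the scatter) lies within the scatter, the expected step for compound 4 is a number no higher from compound 3 to compound 4 (the limit leaves the size open). The estimated value for compound 4 in this assay is 100000 nM, within 50000 nM to 200000 nM, most likely reported again as a limit.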

Compound 4, half-maximal inhibitory concentration: 26000 nM
Estimate against measurement, compound 4: 3.8-fold (0.59 log units) above; measured number below the stated range.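

The swap of 3-nitrophenyl for 4-chlorophenyl gives an at least 3.8-fold lower number from compound 3 to compound 4 (0.58 log units; beyond the scatter), and this step does not match the one on the other core: the same change on two cores in this assay, a 1.4-fold lower number (0.15 log units; within the scatter) from compound 1 to compound 2 and an at least 3.8-fold lower number (0.58 log units; beyond the scatter) from compound 3 to compound 4, at least 2.7-fold (0.43 log units) apart, beyond the scatter of two such steps. The reading for compound 3 is a limit and not a number, so this step has a floor but no fixed size: the limit of > 100000 nM in this assay, at which 1 of the 4 values shown sits. The step measured on one core therefore did not carry over in size to the other, but two pairs do not show why the cores differ or how the change would behave on any further core.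

From the compounds shown here alone, it remains open how an amine or a carboxylic acid in the same place would behave on either core.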